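This account rests on a few compounds, and the source may have more. Where it says the series, first, only, none or still open, it means among the compounds named here.

Measured so far in an ADME assay on L02 cells (Homo sapiens) for antiproliferative activity, read by MTT assay, with a stated time of 48 h; a lower number here means a stronger inhibitor, a higher number a weaker inhibitor:
compound 1 `N#CC1=C(N)Oc2c(c3nc4ccccc4nc3c3ccccc23)C12C(=O)N(Cc1cnnn1-c1ccc(Cl)cc1)c1ccccc12` — > 50000 nM
compound 2 `CC(=O)Nc1ccc(-n2nncc2CN2C(=O)C3(C(C#N)=C(N)Oc4c3c3nc5ccccc5nc3c3ccccc43)c3ccccc32)cc1` — > 50000 nM

In this assay compound 1 gives > 50000 nM, which is a limit of the assay and not a number. In this assay compound 2 likewise gives > 50000 nM, also a limit. Among the compounds with values here, compound 2 therefore stands only at a limit, and the one further value shown for the series is a limit as well. The step that the two limits leave unreadable from compound 1 to compound 2 cannot be sized because the limit of > 50000 nM in this assay, at which 2 of the 2 values shown sit, holds both values.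

Compound 3 `N#CC1=C(N)Oc2c(c3nc4ccccc4nc3c3ccccc23)C12C(=O)N(Cc1cnnn1-c1cccc(S(N)(=O)=O)c1)c1ccccc12` differs from compound 2 by 3-sulfamoylphenyl in place of 4-acetamidophenyl on an aromatic nitrogen. Within the data shown here, the only measured step that bears on this change at the same position is the one from compound 1 to compound 2, and it is unreadable, so no direction or size beyond the scatter can be drawn from it. Compound 3 is accordingly expected to stay at the limit, the estimated step being a step that the limit leaves unreadable from compound 2 to compound 3. The estimate for compound 3 is 60000 nM, with a range from 20000 nM to 200000 nM.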

Compound 3, half-maximal inhibitory concentration: > 50000 nM
Compound 3 ended at the assay's limit (the forecaster's own chance of this, stated with the estimate: 85%); the middle value is on the limit's open side.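

No step among compound 1, compound 2 and compound 3 can be read in this assay, as all three values are a limit of the assay and not a number: the limit of > 50000 nM in this assay, at which 3 of the 3 values shown sit.

The compounds shown leave open how 4-chlorophenyl, 4-acetamidophenyl and 3-sulfamoylphenyl on the aromatic nitrogen rank against one another.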